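From cyclopentyl to 3,4-dimethylphenyl on the amine nitrogen

This account rests on a few compounds, and the source may have more. Where it says the series, first, only, none or still open, it means among the compounds named here.

Of the compounds shown here, three on the shared core have been read in a functional assay on MCF7 cells (Homo sapiens) for inhibition, read by sulforhodamine B assay (on this read-out higher numbers stand for weaker inhibition and lower numbers for stronger inhibition), so far. Compound 2 (`O=C1C(NC2CCCC2)=CC(=O)c2c1nc1n2[C@H]2OC[C@@H](O)[C@H]2OC1`) gives > 16000 nM as a limit and not a number. Compound 1 (`O=C1C=C(NCc2ccccc2)C(=O)c2c1nc1n2[C@H]2OC[C@@H](O)[C@H]2OC1`) gives > 8000 nM as a limit too. Within the data shown here, compound 3 (`O=C1C=C(Nc2ccccc2F)C(=O)c2c1nc1n2[C@H]2OC[C@@H](O)[C@H]2OC1`) gives 3640 nM as the only true number of the three. Compound 2 therefore offers no number of its own as a starting point.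

Still unmeasured is compound 4 (`Cc1ccc(NC2=CC(=O)c3c(nc4n3[C@H]3OC[C@@H](O)[C@H]3OC4)C2=O)cc1C`). The change from compound 2 is 3,4-dimethylphenyl in place of cyclopentyl on an amine nitrogen and amounts to 3,4-dimethylphenyl in place of cyclopentyl on an amine nitrogen. Among the measured compounds shown here, one measured step bears on it: an at least 2.1-fold lower number from compound 1 to compound 3 (0.34 log units; beyond the scatter) comes with 2-fluorophenyl in place of benzyl on an amine nitrogen and lies beyond the scatter. In that pair, as here, a substituted phenyl enters on an amine nitrogen, but a single pair is thin support and its starting point is itself a limit. The expectation also leans on compound 3 with 3640 nM as the closest measured value. A lower number, and so stronger inhibition, is expected in this assay with an at least 3.5-fold lower number from compound 2 to compound 4 (0.55 log units; beyond the scatter) as the estimated step. For compound 4 the expected value is 4500 nM and the estimated range runs from 1800 nM to 14000 nM with a result given only as a limit still possible.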

Compound 4, half-maximal inhibitory concentration: 4950 nM
Compound 4: the middle estimate sits 1.1-fold (0.04 log units) below what was measured; measured number inside the range.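

In this assay, among these compounds, putting 3,4-dimethylphenyl in place of cyclopentyl on the amine nitrogen gives an at least 3.2-fold lower number from compound 2 to compound 4 (0.50 log units; beyond the scatter) and is the first step to start from a non-aromatic ring of carbon only. Compound 2 stands only as a limit, so this step has a floor and not a full size: the limit of > 16000 nM in this assay, at which 1 of the 4 values shown sits. A substituted phenyl on the amine nitrogen now gives a true number twice, in compound 3 at 3640 nM and in compound 4 at 4950 nM. Compound 1 and compound 2, by contrast, are held only as limits, and no compound shown goes against this pattern.

Going by these compounds, whether the aromatic ring itself or its methyl groups carry the step remains open, and an unsubstituted phenyl on the same amine nitrogen would separate the two. Also open, on these data alone, is how a pyridyl group, or a phenyl bearing a methoxy group or a carboxylic acid, would read in this assay on this nitrogen.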